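Notes on the step from compound 1 to compound 3

The source may hold more compounds than are shown below. What is called first, only, known or untested is meant among the compounds shown, and "the series" means these compounds.

Measured so far:
- compound 1, `COc1cc2ncnc(Nc3cccc(B(O)O)c3)c2cc1OC`, in an assay on isolated protein for inhibition of vascular endothelial growth factor receptor 1 (Homo sapiens), read by ELISA, with a stated time of 20 min, tested at 1 uM; on this read-out lower numbers stand for less inhibition and higher numbers for more inhibition at the one concentration tested (going by the name of the read-out): "not active" (no number reported)
- compound 2, `COCCOc1cc2ncnc(Nc3cccc(B(O)O)c3)c2cc1OC`, in the same assay: 19%

Compound 1 has no single number in this assay; for compound 1 the read-out is reported only as "not active" (no number reported), so it stands at the low end of what is shown here. Within the data shown here, compound 2 gives 19% in this assay, a low value in itself; no step between these two compounds is given, and only what each value shows is taken from them. Compound 3, `COC(=O)c1cccc(Nc2ncnc3cc(OC)c(OC)cc23)c1`, differs from compound 1 in one place: a group of 4 heavy atoms (2 carbon, 2 oxygen; no ring) in place of a group of 3 heavy atoms (1 boron, 2 oxygen; no ring), on an aromatic carbon. Going from compound 1 to compound 3, no change beyond the usual scatter of this assay is expected in either direction, at most a small move toward more inhibition. Compound 3 is therefore estimated at 10% in this assay, with an expected range from 0% to 35%.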

Compound 3, a percentage reported as inhibition, at one concentration (the size of the read-out at that concentration, not a potency): "not active" (no number reported)
Compound 3 has no reported number here; no gap can be computed for the estimate.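

Compound 1 gives "not active" (no number reported) and compound 3 gives "not active" (no number reported) in this assay, so no step can be read between compound 1 and compound 3. The compounds shown leave open whether replacing the group on compound 1 with methoxycarbonyl changes inhibition at all. No further data bear on this result.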